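Piperazine cap series: from 3-nitrobenzyl to phenylsulfonyl

The source may report more compounds than this note shows. Statements on the series, on what has been measured and on what is new or still open speak of the compounds shown alone.

Three compounds of the shared core have been run in a functional assay on K562 cells (Homo sapiens) for antiproliferative activity, read by MTT assay and trypan blue exclusion, with a stated time of 72 h; on this read-out higher numbers stand for weaker inhibition and lower numbers for stronger inhibition. Compound 1 `COC(=O)c1ccc(C2SCC(=O)N2c2ccc(N3CCN(Cc4cc(OC)c(OC)c(OC)c4)CC3)cn2)c(OC)c1` gives > 100000 nM, which is a limit of the assay and not a number. Compound 3 `COC(=O)c1ccc(C2SCC(=O)N2c2ccc(N3CCN(Cc4ccc(Cl)c(Cl)c4)CC3)cn2)c(OC)c1` also gives > 100000 nM, again a limit. Compound 2 `COC(=O)c1ccc(C2SCC(=O)N2c2ccc(N3CCN(Cc4cccc([N+](=O)[O-])c4)CC3)cn2)c(OC)c1` is the only member with a measured number, 68700 nM, so it stands alone on the numbers shown. Compound 1 and compound 3 sit at the limit of the assay (the limit of > 100000 nM in this assay, at which 2 of the 3 values shown sit). The steps to it are an at least 1.4-fold lower number from compound 1 to compound 2 (0.16 log units; that floor lies within the scatter) and away from it an at least 1.4-fold higher number from compound 2 to compound 3 (0.16 log units; that floor lies within the scatter), both with floors within the scatter, so neither reads as a real change.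

Compound 4 `COC(=O)c1ccc(C2SCC(=O)N2c2ccc(N3CCN(S(=O)(=O)c4ccccc4)CC3)cn2)c(OC)c1` differs from compound 2 by phenylsulfonyl in place of 3-nitrobenzyl on an amine nitrogen in a ring. For the measured compounds named here, no measured step touches a phenylsulfonyl group, so the change has no direct precedent here. Given that the neighbours of compound 2 in this assay sit at the limit, compound 4 is expected to land near that limit as well, with a 1.5-fold higher number from compound 2 to compound 4 (0.16 log units; within the scatter). The estimate for compound 4 is therefore 100000 nM, ranging from 40000 nM to 300000 nM, with a real chance that only a limit is reported.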

Compound 4, half-maximal inhibitory concentration: 65600 nM
Compound 4: the middle estimate sits 1.5-fold (0.18 log units) above what was measured; the range from low to high includes it.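

In this assay the step is a 1.0-fold lower number from compound 2 to compound 4 (0.02 log units; within the scatter), so a second cap on the amine nitrogen in the ring gives a measured number, and this one is attached through a sulfonyl group, not a saturated chain carbon. Phenylsulfonyl and 3-nitrobenzyl cannot be told apart here, while the step to the other side, an at least 1.5-fold lower number from compound 3 to compound 4 (0.18 log units; that floor lies within the scatter), has a floor that does not separate the two compounds either. Compound 1 and compound 3, also benzyl-capped, stay at a limit and go against any reading that the benzyl link itself gives a number: the limit of > 100000 nM in this assay, at which 2 of the 4 values shown sit.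

Going by these compounds, it remains open what a benzoyl or methanesulfonyl cap, or the free ring amine, would give at this nitrogen. Also open, on these data alone, is whether a substituted phenylsulfonyl, such as 4-methoxyphenylsulfonyl, would move the value beyond the scatter.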